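This account rests on a few compounds, and the source may have more. Where it says the series, first, only, none or still open, it means among the compounds named here.

Working notes on the series. Three compounds have numbers in a physicochemical assay for lipophilicity; on this read-out lower numbers stand for lower lipophilicity and higher numbers for higher lipophilicity. Compound 1 `CCCN(C1=NCCN1)c1c(Br)cccc1Br` gives -0.55. Compound 2 `CCCCCN(C1=NCCN1)c1c(Br)cccc1Br` gives 0.32. Compound 3 `C=CCCN(C1=NCCN1)c1c(Br)cccc1Br` gives -0.63. On these numbers compound 1 sits furthest from compound 2, a number 0.87 log units higher from compound 1 to compound 2 (beyond the scatter), beyond the scatter, and nearest to compound 3, a number 0.08 log units lower from compound 1 to compound 3 (within the scatter), within the scatter, so compounds 1 and 3 cannot be separated in this assay.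

Compound 4 `Brc1cccc(Br)c1N(C1=NCCN1)C1CCCC1` is not yet measured. It differs from compound 1 in one place: cyclopentyl in place of propyl on a nitrogen on an aromatic ring. The measured step that bears on this is the chain extension, a number 0.87 log units higher from compound 1 to compound 2 (beyond the scatter), which shows that ethyl in place of hydrogen on the chain lifts the number modestly. The step back, a number 0.95 log units lower from compound 2 to compound 3 (beyond the scatter), points the same way. Within the data shown here, the cyclopentyl that enters carries more carbon than the propyl it replaces, but closed into a five-membered ring rather than extended as a chain, and the series holds no ring-bearing compound against which such a closure can be read. A rise beyond the scatter is therefore expected, smaller than the chain step. The expected step from compound 1 to compound 4 is a number 0.50 log units higher from compound 1 to compound 4 (beyond the scatter). Compound 4 is estimated at -0.05, between -0.45 and 0.35.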

Compound 4, distribution coefficient: -0.29
Estimate against measurement, compound 4: 0.24 log units above, and the stated range covers the measured number.
By their numbers in this assay, from the lowest: compounds 3, 1 and 4 (each within the scatter of the next, the first and the last beyond it); then compound 2.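

In this assay, cyclopentyl in place of propyl on the nitrogen on the aromatic ring gives a number 0.26 log units higher from compound 1 to compound 4 (within the scatter) even though the ring brings more carbon, so at this place compound 4 cannot be separated from compound 1. Against the open chains the picture is split: a number 0.61 log units lower from compound 2 to compound 4 (beyond the scatter) shows that cyclopentyl reads clearly below pentyl, and a number 0.34 log units higher from compound 3 to compound 4 (beyond the scatter) puts it modestly above but-3-en-1-yl, a small gap given that compound 1 and compound 3 themselves cannot be separated. Nothing on hand accounts for the ring reading below the pentyl chain.

Cyclopentyl is the only ring at this place, so it remains open whether a smaller cyclopropyl, a larger cyclohexyl or a branched chain such as isopropyl would also stay close to the propyl number or move towards the pentyl one. Also open, on these data alone, is how far the number would fall with a hydroxyl or an amine on the ring or chain, and whether the gap between ring and open chain would hold with such a group in place.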